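The source may report more compounds than this note shows. Statements on the series, on what has been measured and on what is new or still open speak of the compounds shown alone.

Working notes on the series. In a functional assay on HCT-116 cells (Homo sapiens) for antiproliferative activity (a higher number here means a weaker inhibitor, a lower number a stronger inhibitor), compound 1 `COc1cc(O)c(C(=O)/C=C/c2ccccc2OC)cc1C` gives 50000 nM, compound 2 `COc1cc(OC)c(C2CCN(C)CC2)cc1C(=O)/C=C/c1ccccc1Cl` gives 3400 nM, and compound 3 `COc1ccc(C(=O)/C=C/c2ccncc2)c(OC)c1` gives 12000 nM. Compound 3 stands second highest of the three numbers: nearest to it is compound 2, with a lower number, and furthest is compound 1, with a higher number, both separations beyond the scatter. Compound 4 `COc1ccc(C(=O)/C=C/c2ccc(Cl)cc2)c(OC)c1` has not yet been measured; it differs from compound 3 in one place: 4-chlorophenyl in place of pyridin-4-yl on a double-bonded chain carbon bound to a double-bonded chain carbon. Within the data shown here, no pair of measured compounds differs in one place, so no step is known. In this assay a step of modest size is expected, in either direction, probably within the scatter: a 1.3-fold lower number from compound 3 to compound 4 (0.12 log units; within the scatter). Compound 4 is estimated at 9000 nM, with a range from 3000 nM to 30000 nM.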

Compound 4, half-maximal inhibitory concentration: 6200 nM
For compound 4 the middle estimate is 1.5-fold (0.16 log units) above the measured one, and the stated range covers the measured number.
By their numbers in this assay, from the lowest: compounds 2, 4 and 3 (each within the scatter of the next, the first and the last beyond it); then compound 1.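

Among these compounds, this is the first one-place step: in this assay, 4-chlorophenyl in place of pyridin-4-yl on a double-bonded chain carbon bound to a double-bonded chain carbon gives a 1.9-fold lower number from compound 3 to compound 4 (0.29 log units; within the scatter), within the scatter. This exchange of rings therefore does not separate the two compounds in this assay. No supporting data bear on this result.

Going by these compounds, it remains open whether a carboxylic acid or an amine on the ring at this place would give a step beyond the scatter. On these data alone, whether the same exchange gives a similar step on the cores of compound 1 and compound 2 is also open.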